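The source may hold more compounds than are shown below. What is called first, only, known or untested is meant among the compounds shown, and "the series" means these compounds.

In an ADME assay on BJ cells (Homo sapiens) for cytotoxicity, with a stated time of 72 h (a lower number here means that less compound is needed, a higher number that more compound is needed for the effect), compound 1, with the structure `COc1ccc(NC(=O)Nc2cc(C)nc3ccccc23)cc1`, gives > 25000 nM, which is a limit of the assay rather than a measured number. Compound 2, `COc1ccc(NC(=O)Nc2cc(C)nc3ccccc23)cc1F`, gives 26000 nM in this assay. Compound 3, `Cc1cc(NC(=O)Nc2cccc([N+](=O)[O-])c2)c2ccccc2n1`, gives > 25000 nM, again a limit. The one step among these three that can be compared is a step that the limit leaves unreadable from compound 1 to compound 2, and its size cannot be read from a limit. Two of the three values sit at the limit of > 25000 nM in this assay, at which 2 of the 3 values shown sit, so the measurements so far show only that none of these compounds is active at the concentrations tested.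

Compound 4, `Cc1cc(NC(=O)Nc2ccc(N(C)C)cc2)c2ccccc2n1`, differs from compound 1 in one place: dimethylamino in place of methoxy on an aromatic carbon. Among the compounds with values here, no measured step covers this exchange, so the only guide is that compound 1 and its close relatives all sit at or near the limit. Compound 4 is therefore expected to give about 30000 nM, within the range 12000 nM to 80000 nM. The expected step that the limit leaves unreadable from compound 1 to compound 4 is no more than the scatter allows.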

Compound 4, half-maximal effective concentration: > 25000 nM
Compound 4 was reported as a limit (the forecaster's own chance of this, stated with the estimate: 70%); the middle value is on the limit's open side.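

In this assay compound 4 gives > 25000 nM, which is a limit of the assay. Within the data shown here, compound 1 is also reported only as a limit, so no step between compound 1 and compound 4 can be read. As far as these compounds go, what stays open is how far past the limit each of these two compounds lies, and whether dimethylamino in place of methoxy makes any difference.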